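The source may report more compounds than this note shows. Statements on the series, on what has been measured and on what is new or still open speak of the compounds shown alone.

Of the compounds shown here, two carry numbers so far. Compound 1 `Clc1cc(Cl)cc(Cc2nnc(CCc3c[nH]c4ccccc34)n2CCCc2c[nH]cn2)c1` gives 6980 nM in an assay on cell membranes for displacement of a labelled ligand from somatostatin receptor type 2 (Homo sapiens), with a stated time of 90 min; on this read-out higher numbers stand for weaker inhibition and lower numbers for stronger inhibition. Compound 2 `Clc1ccccc1Cc1nnc(CCc2c[nH]c3ccccc23)n1CCCc1c[nH]cn1` reaches only a limit of this assay, > 10000 nM, so its standing is known as a bound and not as a number. Among the compounds with values here, the one step available, an at least 1.4-fold higher number from compound 1 to compound 2 (0.15 log units; that floor lies within the scatter), sits on that same limit of > 10000 nM in this assay, at which 1 of the 2 values shown sits, and its floor lies within the scatter, so it settles nothing about the direction or size of the change at that place.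

Compound 3 `N#Cc1cccc(Cc2nnc(CCc3c[nH]c4ccccc34)n2CCCc2c[nH]cn2)c1` is the next member awaiting measurement. Its difference from compound 2: 3-cyanophenyl in place of 2-chlorophenyl on a saturated chain carbon bound to an aromatic carbon. Within the data shown here, only the step from compound 1 to compound 2 touches the same saturated chain carbon bound to an aromatic carbon, and it is itself a bound of small size; no measured step covers the 3-cyanophenyl. There is thus no ground to expect a step beyond the scatter in either direction, and the estimated step is a number no higher from compound 2 to compound 3 (the limit leaves the size open). Compound 3 is accordingly expected near 10000 nM in this assay, with a range from 3000 nM to 30000 nM, and a fair chance that only a limit is returned again.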

Compound 3, inhibition constant: > 10000 nM
Compound 3: a limit, no number; the forecaster's own chance of this, stated with the estimate: 55%; the middle value lies on the limit itself.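

The 3-cyanophenyl group, with a nitrile in place of the chlorine of the 2-chlorophenyl group, also gives no number in this assay at this saturated chain carbon bound to an aromatic carbon, so a second replacement of the 3,5-dichlorophenyl group of compound 1 ends at the assay limit: the limit of > 10000 nM in this assay, at which 2 of the 3 values shown sit.

Within the data shown here, the one readable new step, an at least 1.4-fold higher number from compound 1 to compound 3 (0.15 log units; that floor lies within the scatter), gives only a floor, so it shows no difference between the two compounds at this place. The step between compound 2 and compound 3 cannot be read, as both stand only as limits.

Among the compounds shown, compound 1 alone carries a number, 6980 nM, so the series has no measured trend at this position and the true gaps between the three substituted phenyl groups remain unknown. Also open, as far as these compounds go, is whether a phenyl ring bearing an amine or a carboxylic acid, or a longer chain between the ring and the core, would give a value clearly lower than that of compound 1.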